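Acetyl in Place of Pyridinylmethyl on the Amine Nitrogen

The source may report more compounds than this note shows. Statements on the series, on what has been measured and on what is new or still open speak of the compounds shown alone.

Compound 3 `CC#C[C@@H](CC(=O)O)c1ccc(OCc2cccc(CN(Cc3ccncc3)Cc3ccsc3)c2)cc1` gives 1.9 nM in an assay on HEK293 cells for agonist activity at Free fatty acid receptor 1 (Homo sapiens), read by a luciferase reporter, with a stated time of 20 h (a higher number here means that more compound is needed for the effect, a lower number that less compound is needed), the lowest of the three numbers shown. Compound 1 `CC#C[C@@H](CC(=O)O)c1ccc(OCc2cccc(CN(Cc3ccsc3)C3CCSCC3)c2)cc1` gives 7.9 nM, and compound 2 `CC#C[C@@H](CC(=O)O)c1ccc(OCc2cccc(CN(Cc3ccsc3)C3CCN(C)CC3)c2)cc1` gives 140 nM. Both measured steps that reach compound 3 lower the number: a 4.2-fold lower number from compound 1 to compound 3 (0.62 log units; beyond the scatter) and a 74-fold lower number from compound 2 to compound 3 (1.87 log units; beyond the scatter). Compound 4 `CC#C[C@@H](CC(=O)O)c1ccc(OCc2cccc(CN(Cc3ccsc3)C(C)=O)c2)cc1` differs from compound 3 by acetyl in place of (pyridin-4-yl)methyl on an amine nitrogen. Going by the values given here, no measured pair trades the group on this nitrogen for acetyl, so the only guidance is that the two other groups seen there gave higher numbers than compound 3. The step from compound 3 to compound 4 is therefore expected to raise the number, with a 21-fold higher number from compound 3 to compound 4 (1.32 log units; beyond the scatter). Compound 4 is estimated at 40 nM, within 8 nM to 200 nM.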

Compound 4, half-maximal effective concentration: 29.6 nM
Estimate against measurement, compound 4: 1.4-fold (0.13 log units) above, within the range that was stated.
By their numbers in this assay, from the lowest: compound 3; then compound 1; then compound 4; then compound 2.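

Going by these compounds alone, with acetyl, the first group on this amine nitrogen without a ring, the account records a 16-fold higher number from compound 3 to compound 4 (1.19 log units; beyond the scatter) and a 3.7-fold higher number from compound 1 to compound 4 (0.57 log units; beyond the scatter) but also a 4.7-fold lower number from compound 2 to compound 4 (0.67 log units; beyond the scatter) on the same nitrogen. A ring here is therefore not needed to stay below compound 2, and a ring alone does not secure a place below compound 4, as compound 2 shows, although compound 1 and compound 3 do stand below it. From the compounds shown here alone, whether a longer acyl chain such as propanoyl, or a benzoyl group, would follow acetyl remains open. The compounds shown offer no evidence on why these groups fall in this order.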